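The compounds below may be only part of what the source reports. "The series", "measured", "known", "first", "only" and "open" are said of these compounds alone.

Measured so far:
compound 1, `CC(C)[C@@H]1CC[C@@H](C)C[C@@]12N(C)C(=O)[C@@H]1[C@H]3C(=O)NC(=O)[C@H]3ON12`, 57.2% in a functional assay, read by spectrophotometry, with a stated time of 2 h, tested at 2 mg/mL; on this read-out higher numbers stand for a stronger effect at the one concentration tested and lower numbers for a weaker effect
compound 2, `CC(C)[C@@H]1CC[C@@H](C)C[C@@]12N(C)C(=O)[C@@H]1[C@H]3C(=O)N(C)C(=O)[C@H]3ON12`, 59.9% in this assay

The two values lie within the usual scatter of each other, so compound 2 cannot be set above or below compound 1. Compound 3 is `CC(C)[C@@H]1CC[C@@H](C)C[C@@]12N(C)C(=O)[C@@H]1[C@H]3C(=O)N(c4ccccc4)C(=O)[C@H]3ON12`. The change from compound 2 is phenyl in place of methyl on an amide-type nitrogen in a ring. For the measured compounds named here, one measured step touches the same nitrogen: the swap of hydrogen for methyl, a number 2.7 percentage points higher from compound 1 to compound 2 (within the scatter), stayed within the scatter. On that basis no step beyond the scatter is expected, a number 2.9 percentage points lower from compound 2 to compound 3 (within the scatter), though a phenyl is a larger change than a methyl and the range is kept wide. Compound 3 is estimated at 57%, between 38% and 76%.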

Compound 3, a percentage reported as activity, at one concentration (the size of the read-out at that concentration, not a potency): 41%
Compound 3: the middle estimate sits 16 percentage points above what was measured; the range from low to high includes it.
By their numbers in this assay, from the lowest: compound 3; then compounds 1 and 2 (each within the scatter of the next).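

On this nitrogen, the choice of group can matter: in this assay the phenyl gives a number 18.9 percentage points lower from compound 2 to compound 3 (beyond the scatter) and, set against the amide hydrogen, a number 16.2 percentage points lower from compound 1 to compound 3 (beyond the scatter). Hydrogen and methyl had remained within the scatter of each other, so this is the first change here that can be read as a real loss of effect. Nothing measured here says what lies behind the lower number.

Going by these compounds, it remains open whether the loss belongs to the aromatic ring or simply to a larger carbon group. A longer chain such as butyl, or a phenyl carrying an amine or a carboxylic acid, could help separate these possibilities.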